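Aryl swap on the ring nitrogen: compound 3 to compound 4

The source may report more compounds than this note shows. Statements on the series, on what has been measured and on what is new or still open speak of the compounds shown alone.

Compound 1 `COc1ccccc1Nc1nc(SCc2ccc(C(F)(F)F)cc2)nc2ccccc12` — 14100 nM in a functional assay on PC-3 cells (Homo sapiens) for cytotoxicity, read by MTT assay, with a stated time of 72 h; on this read-out higher numbers stand for weaker inhibition and lower numbers for stronger inhibition
Compound 2 `CCOc1ccccc1Nc1nc(SCc2ccc(C(F)(F)F)cc2)nc2ccccc12` — 26200 nM in this assay
Compound 3 `O=[N+]([O-])c1cccc(Nc2nc(SCc3ccc(C(F)(F)F)cc3)nc3ccccc23)c1` — 13500 nM in this assay

Compound 3 holds the lowest number of the three, but its gaps to compound 1 and compound 2 both lie within the scatter, so no order among them can be read. Compound 4 `COc1ccc(Nc2nc(SCc3ccc(C(F)(F)F)cc3)nc3ccccc23)cc1` differs from compound 3 by 4-methoxyphenyl in place of 3-nitrophenyl on a nitrogen on an aromatic ring. For the measured compounds named here, the steps that bear on this are a 1.0-fold lower number from compound 1 to compound 3 (0.02 log units; within the scatter) and a 1.9-fold lower number from compound 2 to compound 3 (0.29 log units; within the scatter), each an exchange of the aryl group on the same nitrogen, and each within the scatter. Going by the values given here, no measured step pairs a 4-methoxyphenyl with any other group, so the closest reference is compound 1 with its 2-methoxyphenyl. No step beyond the scatter is expected in this assay. Compound 4 is estimated at 14000 nM, range 6000 nM to 35000 nM. This expectation corresponds to a 1.0-fold higher number from compound 3 to compound 4 (0.02 log units; within the scatter).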

Compound 4, half-maximal inhibitory concentration: 16700 nM
The estimate for compound 4 lay 1.2-fold (0.08 log units) below the measured number, within the range that was stated.
By their numbers in this assay, from the lowest: compounds 3, 1, 4 and 2 (each within the scatter of the next).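

With 4-methoxyphenyl on the nitrogen, all three comparisons stay within the scatter: a 1.2-fold higher number from compound 3 to compound 4 (0.09 log units; within the scatter) and a 1.2-fold higher number from compound 1 to compound 4 (0.07 log units; within the scatter) and a 1.6-fold lower number from compound 2 to compound 4 (0.20 log units; within the scatter) (all in this assay). Moving the methoxy group from the 2-methoxyphenyl to the 4-methoxyphenyl arrangement, or exchanging 3-nitrophenyl for 4-methoxyphenyl, therefore separates nothing, and the four aryl groups on this nitrogen fall in no readable order. No measured evidence bears on this result.

Still open, from the compounds shown here alone, is whether an aryl group carrying an amine or a carboxylic acid would give a step beyond the scatter at this nitrogen. The same question stands for a saturated chain in place of the aryl group.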